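The source may hold more compounds than are shown below. What is called first, only, known or untested is meant among the compounds shown, and "the series" means these compounds.

Compound 1 `CCCSc1nc(Cl)c2c(n1)N(Cc1ccccc1)C(C(=O)O)N2` — > 64000 nM in a functional assay on MGC-803 cells (Homo sapiens) for antiproliferative activity, read by MTT assay, with a stated time of 72 h; a lower number here means a stronger inhibitor, a higher number a weaker inhibitor; this is a limit of the assay.
Compound 2 `CCCSc1nc(Cl)c2c(n1)N(CC1CCCCC1)C(C(=O)N1CCN(C)CC1)N2` — > 64000 nM; this too is a limit.
Compound 3 `CCCSc1nc(Cl)c2c(n1)N(CCNC(=O)OC(C)(C)C)C(C(=O)N1CCN(C)CC1)N2` — 59300 nM.

All three compounds share one core and differ in the substituent on the ring nitrogen and in the group on the carbonyl. Compound 1 stands at the limit of > 64000 nM in this assay, at which 2 of the 3 values shown sit, so no number is known for it, only that it is a weak inhibitor in this assay. Among the compounds with values here, the one step between measured compounds, an at least 1.0-fold lower number from compound 2 to compound 3 (0.03 log units; that floor lies within the scatter), concerns the substituent on the ring nitrogen and lies within the scatter; it does not touch the carbonyl position.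

Compound 4 `CCCSc1nc(Cl)c2c(n1)N(Cc1ccccc1)C(C(=O)OCC)N2` is the next member. Relative to compound 1 it carries ethyl in place of hydrogen on an oxygen next to a carbonyl group. Within the data shown here, no measured step bears on this position, and the one step that exists elsewhere is within the scatter. The expected outcome in this assay is therefore no step beyond the scatter, with a fair chance that compound 4 again returns a limit rather than a number. The estimated step that the limit leaves unreadable from compound 1 to compound 4 is small. For compound 4 the value expected in this assay is 70000 nM, with a range from 20000 nM to 200000 nM.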

Compound 4, half-maximal inhibitory concentration: 18500 nM
Compound 4: middle estimate off by 3.8-fold (0.58 log units), on the high side; the whole stated range lies above it.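

In this assay, ethyl in place of hydrogen on an oxygen next to a carbonyl group gives an at least 3.4-fold lower number from compound 1 to compound 4 (0.53 log units; beyond the scatter), the only step in the series shown that lies beyond the scatter and the first reading at this position. Compound 1 gives > 64000 nM, which is a limit: the limit of > 64000 nM in this assay, at which 2 of the 4 values shown sit.
Within the data shown here, the step therefore stands as a floor, its full size cannot be read, and the change from carboxy to ethoxycarbonyl is enough to bring compound 4 to a measured number, whereas the one earlier step, at the substituent on the ring nitrogen, stays within the scatter.

On these data alone, it remains open whether this step belongs to ethyl itself or would appear with any replacement of that hydrogen, which a methyl or a longer chain on the same oxygen, or a primary amide in place of the ester, would help to separate. Also open, as far as these compounds go, is whether ethoxycarbonyl gives a comparable step when the ring nitrogen carries the cyclohexylmethyl group of compound 2 or the protected aminoethyl chain of compound 3.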